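A few compounds are considered here, and "the series" means these few. Any claim that something is new, unique, unknown or untested is made for them only; others in the source may bear on it.

Compound 1 `O=S(=O)(Nc1ccc(-c2nc3ccccc3o2)cc1)c1ccccc1F`: > 100000 nM (a limit of the assay, not a number)
Compound 2 `COc1ccc(Cl)cc1S(=O)(=O)Nc1ccc(-c2nc3ccccc3o2)cc1`: 75000 nM

Both compounds were tested in an ADME assay on HEK293 cells (Homo sapiens) for cytotoxicity, read by resazurin assay, with a stated time of 48 h; a lower number here means that less compound is tolerated, a higher number that more compound is tolerated. Compound 1 stands at the limit of > 100000 nM in this assay, at which 1 of the 2 values shown sits, so its entry is a limit. For the measured compounds named here, compound 2, at 75000 nM, has the only true number so far, which leaves nothing to rank it against.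

Compound 3 `O=S(=O)(Nc1ccc(-c2nc3ccccc3o2)cc1)c1ccc(Cl)c(Cl)c1` has not yet been measured. It shares the core of compound 2 and differs in one group: 3,4-dichlorophenyl in place of 5-chloro-2-methoxyphenyl on a sulfonyl sulfur. Going by the values given here, only one measured step bears on this change, since it also replaces the group on a sulfonyl sulfur: an at least 1.3-fold lower number from compound 1 to compound 2 (0.12 log units; that floor lies within the scatter). That step rests on a limit, so it gives only a floor, and the true size could be larger. This single step is thin evidence, and it offers no reason to expect a change in either direction. The expected result is a 1.1-fold lower number from compound 2 to compound 3 (0.03 log units; within the scatter), which would be no change beyond the scatter. Compound 3 is estimated at 70000 nM, with an expected range from 30000 nM to 100000 nM. It may also prove to reach the limit of the assay and give no number.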

Compound 3, half-maximal cytotoxic concentration: > 100000 nM
Compound 3 gave a limit, no number; the forecaster's own chance of this, stated with the estimate: 30%; middle value at least 1.4-fold (0.15 log units) away from the limit.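

In this assay compound 3 joins compound 1 at a limit of the assay, not a true number: the limit of > 100000 nM in this assay, at which 2 of the 3 values shown sit. Replacing 5-chloro-2-methoxyphenyl with 3,4-dichlorophenyl on the sulfonyl sulfur gives an at least 1.3-fold higher number from compound 2 to compound 3 (0.12 log units; that floor lies within the scatter); the true size could be larger, but this floor alone shows no shift beyond the scatter. The position therefore now has two different groups, 2-fluorophenyl and 3,4-dichlorophenyl, that reach the limit, while 5-chloro-2-methoxyphenyl remains the only group shown with a measured value, and the step between the two limit compounds cannot be read.

How far compound 1 and compound 3 lie past the limit remains unknown, so the compounds shown cannot tell whether these two groups differ at all. From the compounds shown here alone, the effect of an amine or a carboxylic acid on the phenyl ring, or of a longer alkyl chain in place of the ring on the sulfonyl sulfur, also remains open.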